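This account rests on a few compounds, and the source may have more. Where it says the series, first, only, none or still open, it means among the compounds named here.

Measured compounds:
- compound 1, `Cn1cnc2c1c(=O)n(CC(=O)N1CCOCC1)c(=O)n2C`, giving 19.9% in a functional assay on MGC-803 cells (Homo sapiens) for inhibition, read by MTT assay, with a stated time of 48 h, tested at 20 uM; a lower number here means less inhibition, a higher number more inhibition at the concentration tested (going by the name of the read-out)
- compound 2, `CN1CCN(C(=O)Cn2c(=O)c3c(ncn3C)n(C)c2=O)CC1`, giving 8.6% in this assay

Among the compounds with values here, compound 2 is the lower of the two numbers in this assay; its nearest neighbour is compound 1, and the one measured step, a number 11.3 percentage points lower from compound 1 to compound 2 (beyond the scatter), runs downward beyond the scatter when 4-methylpiperazin-1-yl replaces morpholin-4-yl on the carbonyl carbon.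

Compound 3, `C=CC(=O)N1CCN(C(=O)Cn2c(=O)c3c(ncn3C)n(C)c2=O)CC1`, is the unmeasured compound. It differs from compound 2 in this way: vinylcarbonyl in place of methyl on an amine nitrogen in a ring. Within the data shown here, the change sits on the amine nitrogen of the six-membered ring with two nitrogens, a place that none of the measured steps touches; the only step known concerns the exchange of the whole ring on the carbonyl carbon, not a group on its nitrogen. Among the measured compounds shown here, no measured step therefore bears on this change, and the account has nothing to rest a direction on beyond the low standing of compound 2 itself.

For compound 3 the expected step is a number 6.4 percentage points higher from compound 2 to compound 3 (within the scatter), a move not reliably beyond the scatter. Compound 3 is thus estimated at 15%, with a range from 0% to 35%.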

Compound 3, a percentage reported as inhibition, at one concentration (the size of the read-out at that concentration, not a potency): 1.3%
Compound 3: middle estimate off by 13.7 percentage points, on the high side; the measured number falls inside the stated range.
By their numbers in this assay, from the lowest: compounds 3 and 2 (each within the scatter of the next); then compound 1.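

In this assay, the change on the amine nitrogen in the ring, vinylcarbonyl in place of methyl, gives a number 7.3 percentage points lower from compound 2 to compound 3 (within the scatter), so the two groups cannot be told apart at this position. Within the data shown here, the only earlier step exchanged the whole ring on the carbonyl carbon and gave a number 11.3 percentage points lower from compound 1 to compound 2 (beyond the scatter), whereas this result is the first reading of a change made on the ring nitrogen itself, and it leaves compound 3 within the scatter of compound 2. Nothing among the data given explains the result of this change at the ring nitrogen.

Going by these compounds, it remains open whether a propanoyl group, the saturated counterpart of vinylcarbonyl, would read the same on this nitrogen, and what a free amine, a carboxylic acid or a longer chain would do there. On these data alone, with a single percentage at one concentration for each compound, it also remains open how compound 2 and compound 3 would compare across a range of concentrations.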